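The source may hold more compounds than are shown below. What is called first, only, known or untested is meant among the compounds shown, and "the series" means these compounds.

Of the compounds shown here, three built on one shared core have been measured in a functional assay on MDA-MB-231 cells (Homo sapiens) for antiproliferative activity, read by MTT assay, with a stated time of 72 h; on this read-out higher numbers stand for weaker inhibition and lower numbers for stronger inhibition. Compound 1 `O=C(CCc1cccc2c1B(O)OC2)NCc1ccccc1` carries a benzyl group on the amide nitrogen. In this assay compound 1 reaches only the limit of > 100000 nM, which is a limit of the assay rather than a number (the limit of > 100000 nM in this assay, at which 1 of the 3 values shown sits). Compound 2 `O=C(CCc1cccc2c1B(O)OC2)Nc1ccc(Cl)cc1` bears a 4-chlorophenyl on that nitrogen instead and gives 3600 nM; compound 3 `O=C(CCc1cccc2c1B(O)OC2)Nc1cccc(I)c1` bears a 3-iodophenyl and gives 5300 nM. Two steps are large: an at least 27-fold lower number from compound 1 to compound 2 (1.44 log units; beyond the scatter) and an at least 18-fold lower number from compound 1 to compound 3 (1.27 log units; beyond the scatter). The third is small: a 1.5-fold higher number from compound 2 to compound 3 (0.17 log units; within the scatter). Of the two numbers shown, compound 3 has the higher one, but its nearest neighbour, compound 2, sits within the scatter of it, so the two cannot be ordered.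

Compound 4 `N#Cc1cccc(-c2cccc(NC(=O)CCc3cccc4c3B(O)OC4)c2)c1` is the next step. 3-cyanophenyl in place of iodo on an aromatic carbon Of the measured steps, only the exchange of one halogenated phenyl for another, a 1.5-fold higher number from compound 2 to compound 3 (0.17 log units; within the scatter), concerns a swap on the aryl amide, and it stayed within the scatter. The large steps from compound 1 concern the change from benzyl to aryl, which compound 4 keeps. For the measured compounds named here, no measured step covers the entry of a cyanophenyl group. Compound 4 is therefore expected to sit near compound 3, with a step of a 1.3-fold lower number from compound 3 to compound 4 (0.12 log units; within the scatter) that stays within the scatter. The estimate for compound 4 in this assay is 4000 nM, between 1300 nM and 15000 nM.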

Compound 4, half-maximal inhibitory concentration: 110 nM
Compound 4: the middle estimate sits 36-fold (1.56 log units) above what was measured; the measured number lies below the stated range.
By their numbers in this assay, from the lowest: compound 4; then compounds 2 and 3 (each within the scatter of the next). At a limit, above all of these: compound 1.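

In this assay, replacing the iodo group with 3-cyanophenyl gives a 48-fold lower number from compound 3 to compound 4 (1.68 log units; beyond the scatter), a large step and the first at this aromatic carbon to go well beyond the scatter. For the compounds shown here, the only earlier exchange among aryl amides, a 1.5-fold higher number from compound 2 to compound 3 (0.17 log units; within the scatter), stayed within the scatter, so the earlier compounds could not show that the group on the aryl ring of the amide can make such a difference; compound 4 shows that it can, at least when a single iodine atom gives way to a group of eight heavy atoms that brings an extra aromatic ring and a nitrile. Nothing measured here gives a property of these groups that would account for the step.

Because the ring and the nitrile enter together, these compounds cannot say which of them matters, or whether both are needed; an unsubstituted phenyl at this carbon, or a phenyl carrying an amine or a carboxylic acid in place of the nitrile, would begin to separate the two. From the compounds shown here alone, it also remains open whether the same 3-cyanophenyl group would have a similar effect at another carbon of the ring.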